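Swapping Two Ring Stereocentres in a Peroxide Acid

The source may hold more compounds than are shown below. What is called first, only, known or untested is meant among the compounds shown, and "the series" means these compounds.

Within the data shown here, compound 2 `C=C1CCCC(C)(C)C1CC[C@@]1(C)CC[C@H]([C@@H](C)C(=O)O)OO1` holds the only number in this set: in a functional assay on UO-31 cells (Homo sapiens) for inhibition (a lower number here means a stronger inhibitor of growth, a higher number a weaker inhibitor of growth), compound 2 gives 4310 nM. Compound 1 `COC(=O)[C@H](C)[C@H]1CC[C@@](C)(CCC2=C(C)CCCC2(C)C)OO1` gives in this assay the value > 23700 nM, which is a limit of the assay and not a number. Compound 3 `C=C1CCCC(C)(C)C1CC[C@]1(C)CC[C@@H]([C@@H](C)C(=O)O)OO1` differs from compound 2 in this way: the two compounds have the same atoms and bonds; at least one stereo element is drawn with a configuration in one of them and without one in the other: 2 of 4 stereo elements differ; a stereocentre at a saturated ring carbon is drawn S in compound 2 and R in compound 3; a stereocentre at a saturated ring carbon is drawn R in compound 2 and S in compound 3. Among the measured compounds shown here, no step between two measured compounds is available here, so the size and direction of such a change cannot be read from the data. Compound 3 is therefore expected to land close to compound 2, with an estimated step of a 1.4-fold higher number from compound 2 to compound 3 (0.14 log units; within the scatter), giving an estimate of 6000 nM, between 1500 nM and 24000 nM.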

Compound 3, concentration for 50% growth inhibition: > 10000 nM
Compound 3 ended at the assay's limit; the forecaster's own chance of this, stated with the estimate: 30%; middle value at least 1.6-fold (0.22 log units) away from the limit.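

In this assay swapping the two ring stereocentres alone gives an at least 2.3-fold higher number from compound 2 to compound 3 (0.36 log units; beyond the scatter) while atoms and bonds stay the same. Among these compounds, the spatial arrangement at these two ring carbons therefore matters for growth inhibition in these cells, which the earlier compounds could not show. Compound 3 stands at a limit of the assay, not at a number: the limit of > 10000 nM in this assay, at which 1 of the 3 values shown sits.

Left open is the true size of this step, and whether each ring stereocentre counts on its own. Also open, going by these compounds, is whether an amide in place of the carboxylic acid would keep the growth inhibition of compound 2.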